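The source may report more compounds than this note shows. Statements on the series, on what has been measured and on what is new or still open speak of the compounds shown alone.

Working notes on the oxazolidinone series.

Of the compounds shown here, two have a number so far. Compound 1 `O=C(CCCCCc1ccc(Br)cc1)N1CCOC1=O` carries a bromophenyl chain on the shared core; in an assay on HEK293 cells for inhibition of N-acylethanolamine-hydrolyzing acid amidase (Rattus norvegicus), read by LC-MS, with a stated time of 30 min (on this read-out higher numbers stand for weaker inhibition and lower numbers for stronger inhibition), compound 1 gives 8510 nM. Compound 2 `Cc1ccc(Oc2ccc(C(=O)N3CCOC3=O)cc2)cc1` carries a diaryl ether instead; in this assay compound 2 gives 6400 nM. Of these two numbers that of compound 2 is the lowest, and its nearest neighbour is compound 1, whose number lies within the scatter of it, so no order between them is claimed.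

The next step leads from compound 2 to compound 3 `O=C1OCCN1C(=O)c1ccc(OC2CCOCC2)cc1`, which has not yet been measured in this assay. The change is oxan-4-yl in place of 4-methylphenyl on an oxygen on an aromatic ring. Going by the values given here, no step between two measured compounds is available to calibrate this change, so the expectation rests on compound 2 alone.

The step is expected to be small and towards a higher number, a 1.7-fold higher number from compound 2 to compound 3 (0.24 log units; within the scatter), probably not far beyond the scatter. For compound 3 the estimated value in this assay is 11000 nM, with a range from 3500 nM to 35000 nM.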

Compound 3, half-maximal inhibitory concentration: 330 nM
Compound 3: the middle estimate sits 33-fold (1.52 log units) above what was measured; the whole stated range lies above it.
By their numbers in this assay, from the lowest: compound 3; then compounds 2 and 1 (each within the scatter of the next).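

On an oxygen on an aromatic ring, oxan-4-yl in place of 4-methylphenyl gives the first difference in this series that stands beyond the scatter in this assay with a 19-fold lower number from compound 2 to compound 3 (1.29 log units; beyond the scatter) as a large step. This place therefore responds strongly to the group on the oxygen, and a six-membered aromatic ring of carbon only is not required there for the lower number, which here goes with a non-aromatic ring holding 1 hetero atom. The entering group also differs in counting 6 heavy atoms against 7 and 1 hydrogen-bond acceptor against 0, yet nothing at hand separates these differences or gives a reason for the size of the step.

Going by these compounds, with a single pair, it stays open whether the ring oxygen of oxan-4-yl or the loss of the aromatic ring carries the step, a question that cyclohexyl or piperidin-4-yl on the same oxygen would address. On these data alone, it also stays open whether a shorter chain such as ethyl on that oxygen would give a similar number, and how far the step holds for other groups at this place.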